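Boronate chalcone series: capping the hydroxy of compound 3

The compounds below may be only part of what the source reports. "The series", "measured", "known", "first", "only" and "open" are said of these compounds alone.

Measured so far:
compound 1 `O=C(/C=C/c1ccc2c(c1)B(O)OC2)c1ccccc1` — 6100 nM
compound 2 `O=C(/C=C/c1ccc2c(c1)B(O)OC2)c1ccccc1F` — 4200 nM
compound 3 `O=C(/C=C/c1ccc2c(c1)B(O)OC2)c1ccccc1O` — 77900 nM

In a functional assay on HCT-116 cells (Homo sapiens) for cytotoxicity, read by MTT assay, with a stated time of 48 h (on this read-out lower numbers stand for stronger inhibition and higher numbers for weaker inhibition), compound 3 stands highest of the three numbers. The step of a 13-fold higher number from compound 1 to compound 3 (1.11 log units; beyond the scatter) is large, and the step of a 19-fold higher number from compound 2 to compound 3 (1.27 log units; beyond the scatter) is larger still; both lie beyond the scatter. The step of a 1.5-fold lower number from compound 1 to compound 2 (0.16 log units; within the scatter) is within the scatter, so compound 1 and compound 2 are not separated by this read-out.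

Compound 4 `COCOc1ccccc1C(=O)/C=C/c1ccc2c(c1)B(O)OC2` differs from compound 3 by methoxymethyl in place of hydrogen on an oxygen on an aromatic ring. Going by the values given here, no measured step replaces the hydrogen on this oxygen with anything, so no direct precedent exists. Among the compounds with values here, the steps that bear on the change are the two into compound 3: the hydroxy is the only group that carries a large rise in number, and compound 4 removes its hydrogen while keeping the oxygen. A return toward the numbers of compound 1 and compound 2 is therefore expected, though with wide uncertainty because the size of a 19-fold higher number from compound 2 to compound 3 (1.27 log units; beyond the scatter) shows how sensitive this position is.

The expected step is a 3.9-fold lower number from compound 3 to compound 4 (0.59 log units; beyond the scatter). For compound 4 the estimate is 20000 nM, with a range from 5000 nM to 80000 nM.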

Compound 4, half-maximal inhibitory concentration: 10200 nM
For compound 4 the middle estimate is 2.0-fold (0.29 log units) above the measured one; the range from low to high includes it.
By their numbers in this assay, from the lowest: compounds 2, 1 and 4 (each within the scatter of the next, the first and the last beyond it); then compound 3.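

In this assay, methoxymethyl in place of hydrogen on the oxygen gives a 7.6-fold lower number from compound 3 to compound 4 (0.88 log units; beyond the scatter), so among these compounds the high number goes with the free hydroxy and not with an oxygen on the aromatic ring as such. The capped compound also sits close to the compound without a substituent at this place, with a 1.7-fold higher number from compound 1 to compound 4 (0.22 log units; within the scatter), which shows that this place accepts methoxymethoxy, a group larger than any of the earlier substituents, without a separable change from hydrogen. Fluoro remains distinguishable from the cap, with a 2.4-fold higher number from compound 2 to compound 4 (0.39 log units; beyond the scatter), so the recovery from compound 3 is substantial but leaves a modest gap to compound 2. Nothing available here bears on the reason for these differences. The compounds shown leave open whether a smaller cap such as methyl, a longer alkyl ether chain or an acetyl ester on the same oxygen would behave like methoxymethyl. They also leave open what an amine or a carboxylic acid at this place would give, and whether the hydroxy penalty appears on any core other than the one shared here.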